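From bromo to nitro on the shared core

The compounds below may be only part of what the source reports. "The series", "measured", "known", "first", "only" and "open" are said of these compounds alone.

In a functional assay on HCT-116 cells (Homo sapiens) for antiproliferative activity, read by MTT assay, with a stated time of 72 h (on this read-out lower numbers stand for stronger inhibition and higher numbers for weaker inhibition), compound 1 (`COc1ccc(/C=C2/CN(C)/C(=N/c3ccc(C)cc3)S2)cc1`) gives 11100 nM while compound 2 (`COc1ccc(/C=C2/CN(C)/C(=N/c3ccc(OC)cc3)S2)cc1`) gives 15900 nM and compound 3 (`COc1ccc(/C=C2/CN(C)/C(=N/c3ccc(Br)cc3)S2)cc1`) gives 8900 nM on the same read-out. These three values lie within the scatter of each other, so compound 3 stands level with the other two. Compound 4 (`COc1ccc(/C=C2/CN(C)/C(=N/c3ccc([N+](=O)[O-])cc3)S2)cc1`) carries nitro in place of bromo on an aromatic carbon para to a large group. The measured steps at this same place are a 1.2-fold lower number from compound 1 to compound 3 (0.10 log units; within the scatter) and a 1.8-fold lower number from compound 2 to compound 3 (0.25 log units; within the scatter) and a 1.4-fold higher number from compound 1 to compound 2 (0.16 log units; within the scatter) and each of them stays within the scatter. Within the data shown here, none of the measured compounds carries nitro, so these steps are the only guide. No step beyond the scatter is therefore expected in this assay for this change. The estimate means a 1.1-fold higher number from compound 3 to compound 4 (0.03 log units; within the scatter) as the expected step. The estimate for compound 4 is 9500 nM and the range 3500 nM to 25000 nM is expected to hold the measurement.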

Compound 4, half-maximal inhibitory concentration: 10200 nM
Estimate against measurement, compound 4: 1.1-fold (0.03 log units) below; the measured number falls inside the stated range.
By their numbers in this assay, from the lowest: compounds 3, 4, 1 and 2 (each within the scatter of the next).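

In this assay, nitro brings more heavy atoms to this place than bromo and adds hydrogen-bond acceptors, yet the number stays within the scatter of all three earlier compounds (a 1.1-fold higher number from compound 3 to compound 4 (0.06 log units; within the scatter)) (a 1.6-fold lower number from compound 2 to compound 4 (0.19 log units; within the scatter)) (a 1.1-fold lower number from compound 1 to compound 4 (0.04 log units; within the scatter)). Methyl, methoxy, bromo and nitro on this aromatic carbon, in compounds 1, 2, 3 and 4, therefore stand level, so the swap from bromo to nitro widens the range of groups compared here without separating any of them. Nothing at hand explains this lack of separation. On these data alone, whether an amine, a carboxylic acid or a longer chain at this place would stand apart from these four remains open. Also open, as far as these compounds go, is whether a change elsewhere on the shared core would move the number beyond the scatter.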